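The compounds below may be only part of what the source reports. "The series", "measured", "known", "first", "only" and "open" are said of these compounds alone.

Working notes on a small cytotoxicity series.

Compound 1 `O=[N+]([O-])c1ccc(Oc2c(Cl)cc(S(=O)(=O)N/C(=N\O)Nc3ccc(Cl)cc3)cc2Cl)cc1` and compound 2 `O=[N+]([O-])c1ccc(Oc2c(Cl)cc(S(=O)(=O)N/C(=N\O)Nc3ccc(Cl)cc3)cc2Cl)c(Cl)c1` share one core; compound 3 `Cc1ccc(S(=O)(=O)/N=C(\S)Nc2ccc(Cl)cc2)cc1` and compound 4 `Cc1ccc(S(=O)(=O)/N=C(\S)Nc2ccc(Cl)c(Cl)c2)cc1` share another. How the two cores differ is not broken down here. In a functional assay on KB cells (Homo sapiens) for cytotoxicity (a higher number here means a weaker inhibitor, a lower number a stronger inhibitor), compound 1 gives 12 ug/mL, while compound 2 gives 7 ug/mL; the change between them is chloro in place of hydrogen on an aromatic carbon, and it made a 1.7-fold lower number from compound 1 to compound 2 (0.23 log units; within the scatter). In this assay compound 3 gives 80 ug/mL, the highest of the three numbers, beyond the scatter from compound 1 and compound 2 alike. Compound 4 is not yet measured. It differs from compound 3 by chloro in place of hydrogen on an aromatic carbon, the same kind of change as from compound 1 to compound 2, though the surroundings differ: there the entering group sits ortho to a large group and meta to a nitro group, here ortho to a chloro group and meta to a large group. Because a 1.7-fold lower number from compound 1 to compound 2 (0.23 log units; within the scatter) stayed within the scatter, the step expected in this assay is a 1.5-fold lower number from compound 3 to compound 4 (0.16 log units; within the scatter), resting on that single precedent only. The estimate for compound 4 in this assay is 55 ug/mL, with a range from 25 ug/mL to 120 ug/mL.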

Compound 4, half-maximal inhibitory concentration: 41 ug/mL
Beside the measured number, compound 4's estimate is 1.3-fold (0.13 log units) above it; the measured number falls inside the stated range.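

In this assay, chloro in place of hydrogen on an aromatic carbon gives a 2.0-fold lower number from compound 3 to compound 4 (0.29 log units; within the scatter), and the comparison with the earlier step reads: the same change on two cores in this assay, a 1.7-fold lower number (0.23 log units; within the scatter) from compound 1 to compound 2 and a 2.0-fold lower number (0.29 log units; within the scatter) from compound 3 to compound 4, 1.1-fold (0.06 log units) apart, within the scatter of two such steps. On these two cores, then, the change carries over with a step of similar size, even though the entering chloro group has different surroundings in each pair. This does not show that the change has a real effect on either core, as each step lies within the scatter, and two pairs give no rule for any other core in the series.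

The compounds shown leave open whether a bromo, methyl or methoxy group, or an amine, in place of that hydrogen would give a step beyond the scatter. They also leave open whether a step of this size would hold for chloro on a different aromatic carbon of either core.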